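This account rests on a few compounds, and the source may have more. Where it says the series, first, only, none or still open, it means among the compounds named here.

Measured so far in a functional assay on HepG2 cells (Homo sapiens) for antiproliferative activity, read by MTT assay, with a stated time of 72 h; on this read-out higher numbers stand for weaker inhibition and lower numbers for stronger inhibition:
- compound 1 `COc1cc2c(Nc3ccc(C#N)cc3)ncnc2cc1OCCCN(C)C`: > 100000 nM
- compound 2 `COc1cc2c(Nc3ccc(C#N)cc3)ncnc2cc1OCCCN1CCC(O)CC1`: 67900 nM

Compound 1 gives only a limit of the assay, not a number: it sits at the limit of > 100000 nM in this assay, at which 1 of the 2 values shown sits. Compound 2 is therefore the one compound in this assay with a number shown, and in this assay compound 2 gives 67900 nM. Among the compounds with values here, the one measured step, an at least 1.4-fold lower number from compound 1 to compound 2 (0.16 log units; that floor lies within the scatter), exchanges the amine at the end of the three-carbon chain and reaches only a floor that stays within the scatter.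

Compound 3 `COc1cc2c(Nc3ccc(C#N)cc3)ncnc2cc1OCCCN1CCC(c2ccccc2)CC1` differs from compound 2 by phenyl in place of hydroxy on a saturated ring carbon. Within the data shown here, no measured step alters a substituent on the piperidine ring; the only step available concerns the amine itself and is of undetermined size beyond its floor. Nothing among the shown steps supports a change beyond the scatter in this assay, so the expectation for compound 3 is anchored on compound 2 with a wide range and an estimated step of a 1.9-fold lower number from compound 2 to compound 3 (0.29 log units; within the scatter). Compound 3 is estimated to give 35000 nM in this assay, with the range 8000 nM to 100000 nM.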

Compound 3, half-maximal inhibitory concentration: 4610 nM
For compound 3 the middle estimate is 7.6-fold (0.88 log units) above the measured one, outside the stated range (below it).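

In this assay, the saturated ring carbon three ring bonds from the ring nitrogen is the first place in the series where a change is shown to move the number beyond the scatter, with phenyl in place of hydroxy giving a 15-fold lower number from compound 2 to compound 3 (1.17 log units; beyond the scatter). The floor for exchanging dimethylamino for 4-hydroxypiperidin-1-yl stayed within the scatter, whereas exchanging it for 4-phenylpiperidin-1-yl gives an at least 21-fold lower number from compound 1 to compound 3 (1.33 log units; beyond the scatter), so the amine at the end of the chain is not indifferent in this assay once the ring carries phenyl. Compound 1 remains a limit of the assay, so this second step is a floor and its full size stays unknown: the limit of > 100000 nM in this assay, at which 1 of the 3 values shown sits.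

Going by these compounds, whether a cyclohexyl group or a plain hydrogen on the same ring carbon would give a similar number remains open, so the step cannot yet be assigned to the arrival of the aromatic ring or to the departure of the hydroxy. Also open, on these data alone, is whether 4-phenylpiperidin-1-yl would hold its number on a longer chain.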